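Swapping Phenyl for Cyclohexyl on an Amide Nitrogen

The source may hold more compounds than are shown below. What is called first, only, known or untested is meant among the compounds shown, and "the series" means these compounds.

Compound 1 `C#CCn1cc(C(=O)NC(CC(=O)Nc2ccccc2)c2ccccc2)c(=O)c2cc(F)c(Cl)nc21` was tested in a functional assay on DU-145 cells (Homo sapiens) for cytotoxicity, read by MTT assay, with a stated time of 72 h (on this read-out lower numbers stand for stronger inhibition and higher numbers for weaker inhibition), and gave 5900 nM. Going by the values given here, its only companion is compound 2 `C#CCn1cc(C(=O)NC(CC(=O)Nc2ccccn2)c2ccccc2)c(=O)c2ccc(Cl)nc21`, which in this assay gave 4900 nM. Compound 1 has the larger of the two numbers, but the gap is within the usual scatter, so no ranking follows. Compound 3 `C#CCn1cc(C(=O)NC(CC(=O)NC2CCCCC2)c2ccccc2)c(=O)c2cc(F)c(Cl)nc21` differs from compound 1 in one place: cyclohexyl in place of phenyl on an amide-type nitrogen. Among the compounds with values here, no measured pair shows this change, so the step is expected to be small, a 1.0-fold higher number from compound 1 to compound 3 (0.01 log units; within the scatter), in either direction or none beyond the scatter. Compound 3 is expected to give about 6000 nM, within 2500 nM to 15000 nM.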

Compound 3, half-maximal inhibitory concentration: 8030 nM
For compound 3 the middle estimate is 1.3-fold (0.13 log units) below the measured one; low and high end bracket the measured number.
By their numbers in this assay, from the lowest: compounds 2, 1 and 3 (each within the scatter of the next).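

Cyclohexyl in place of phenyl on this amide-type nitrogen gives a 1.4-fold higher number from compound 1 to compound 3 (0.13 log units; within the scatter) in this assay. Going by these compounds alone, this pair is the first direct look at this position, and on this read-out the aromatic ring and the non-aromatic ring of six carbons cannot be told apart. No available evidence explains the result. Going by these compounds, whether this tolerance extends to very different groups on the same nitrogen stays open. A small methyl, a longer alkyl chain or a ring carrying an amine or a carboxylic acid could still give quite different numbers.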